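Bromo for chloro on the ethenyl-linked aryl arm

A few compounds are considered here, and "the series" means these few. Any claim that something is new, unique, unknown or untested is made for them only; others in the source may bear on it.

Three members of the series share one core and differ only in the arm carried on its five-membered heteroaromatic ring. Compound 1 `NS(=O)(=O)c1cc(-c2nnc(Cn3cc(-c4ccccc4)nn3)o2)c(Cl)cc1SCc1ccccc1` gives 170000 nM in a functional assay on MCF7 cells (Homo sapiens) for cytotoxicity, read by MTT assay, with a stated time of 72 h; on this read-out higher numbers stand for weaker inhibition and lower numbers for stronger inhibition. Compound 2 `NS(=O)(=O)c1cc(-c2nnc(CNS(=O)(=O)c3ccc(Cl)cc3)o2)c(Cl)cc1SCc1ccccc1` gives 30000 nM in this assay, a move described by a 5.7-fold lower number from compound 1 to compound 2 (0.75 log units; beyond the scatter). Compound 3 `NS(=O)(=O)c1cc(-c2nnc(/C=C/c3ccc(Cl)cc3)o2)c(Cl)cc1SCc1ccccc1` gives 11000 nM in this assay; the moves here are a 15-fold lower number from compound 1 to compound 3 (1.19 log units; beyond the scatter) and a 2.7-fold lower number from compound 2 to compound 3 (0.44 log units; beyond the scatter). Compound 3 therefore stands lowest of the three numbers, with compound 2 nearest and compound 1 furthest, both gaps beyond the scatter.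

Compound 4 `NS(=O)(=O)c1cc(-c2nnc(/C=C/c3ccc(Br)cc3)o2)c(Cl)cc1SCc1ccccc1` is not yet measured. Relative to compound 3 the change is bromo in place of chloro on an aromatic carbon. For the measured compounds named here, none of the measured steps touches this position; all three concern exchanges of the whole arm, and each of them was large or modest, whereas the present change is a single halogen exchange at the far end of an arm that is otherwise retained. Going by the values given here, no measured step therefore bears directly on it, and the step is expected to lie within the scatter, a 1.1-fold lower number from compound 3 to compound 4 (0.04 log units; within the scatter), with no clear direction.

For compound 4 the expected value in this assay is 10000 nM, within a range from 4000 nM to 25000 nM.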

Compound 4, half-maximal inhibitory concentration: 13000 nM
Compound 4: the middle estimate sits 1.3-fold (0.11 log units) below what was measured; low and high end bracket the measured number.
By their numbers in this assay, from the lowest: compounds 3 and 4 (each within the scatter of the next); then compound 2; then compound 1.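

In this assay, bromo in place of chloro on the aromatic carbon para to a large group is the only step shown that keeps the arm and alters just its halogen, and it gives a 1.2-fold higher number from compound 3 to compound 4 (0.07 log units; within the scatter) with no order between the 4-chlorophenyl and 4-bromophenyl arms. The separation from the other arms also holds with bromo, with a 2.3-fold lower number from compound 2 to compound 4 (0.36 log units; beyond the scatter) and a 13-fold lower number from compound 1 to compound 4 (1.12 log units; beyond the scatter) showing that the standing of the ethenyl-linked arm in this series does not rest on chloro alone. Nothing shown gives a reason for any of these numbers.

As far as these compounds go, it remains open whether fluoro, methoxy, an amine or a carboxylic acid at this same place on the ring would also stay within the scatter of compound 3, or whether only the halogens tested behave this way. From the compounds shown here alone, it is equally open whether a longer chain or a saturated ethyl link in place of the ethenyl link would keep the number of compound 4 or move it toward that of compound 2.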